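Ortho-phenyl in place of chloro on the benzyl ether

A few compounds are considered here, and "the series" means these few. Any claim that something is new, unique, unknown or untested is made for them only; others in the source may bear on it.

Measured compounds:
Compound 1, `CC(C)(N)C(=O)N[C@H](COCc1ccc(F)cc1F)c1nnnn1CCOC(=O)NCCCCO`: 0.42 nM
Compound 2, `CC(C)(N)C(=O)N[C@H](COCc1ccccc1Cl)c1nnnn1CCOC(=O)NCCCCO`: 0.45 nM

In a functional assay on cells for inhibition of growth hormone secretagogue receptor type 1 (Homo sapiens), read by FLIPR and calcium flux (on this read-out lower numbers stand for an effect already at smaller amounts and higher numbers for an effect only at larger amounts of compound), compound 1 gives 0.42 nM and compound 2 gives 0.45 nM. Compound 2 holds the highest of the two numbers, but its nearest neighbour is compound 1 with a 1.1-fold higher number from compound 1 to compound 2 (0.03 log units; within the scatter), so the two cannot be told apart on this read-out.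

Compound 3, `CC(C)(N)C(=O)N[C@H](COCc1ccccc1-c1ccccc1)c1nnnn1CCOC(=O)NCCCCO`, is not yet measured. It differs from compound 2 by phenyl in place of chloro on an aromatic carbon. Among the measured compounds shown here, the one measured step, 2-chlorophenyl in place of 2,4-difluorophenyl, ran a 1.1-fold higher number from compound 1 to compound 2 (0.03 log units; within the scatter) and speaks only to small changes on that ring. For the measured compounds named here, no measured step covers a phenyl entering at this aromatic carbon, and the entering group is far larger than anything varied so far, so the data give no firm direction. Given the tolerance seen in compound 1 and compound 2, a modest loss is thought more likely than a gain, but the expected change from compound 2 to compound 3 is a 3.3-fold higher number from compound 2 to compound 3 (0.52 log units; beyond the scatter) with wide uncertainty. Compound 3 is therefore estimated at 1.5 nM, between 0.3 nM and 8 nM.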

Compound 3, half-maximal effective concentration: 0.34 nM
Compound 3: the middle estimate sits 4.4-fold (0.64 log units) above what was measured; low and high end bracket the measured number.
By their numbers in this assay, from the lowest: compounds 3, 1 and 2 (each within the scatter of the next).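

In this assay, among the compounds shown here, the exchange of chloro for phenyl on this aromatic carbon gives a 1.3-fold lower number from compound 2 to compound 3 (0.12 log units; within the scatter) and so stays within the scatter, which shows that this position accepts a whole six-membered aromatic ring of carbon only, a far bigger change than the swap of halogens seen between the earlier compounds. The comparison with the 2,4-difluorophenyl group reads the same way, with a 1.2-fold lower number from compound 1 to compound 3 (0.09 log units; within the scatter) on the same read-out, so all three aryl groups on the benzyl ether fall within the scatter of one another and the earlier tolerance on this ring now reaches well beyond small substituents. Nothing available here accounts for this tolerance.

The compounds shown hold no group at this aromatic carbon that moves the number beyond the scatter, so the limit of what the position accepts remains unknown. From the compounds shown here alone, whether a phenyl carrying a carboxylic acid or an amine, or a longer chain such as benzyl at the same carbon, would keep the number in this range stays open.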